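Ether series, cytotoxicity: the isopropyl to isobutyl step

The compounds below may be only part of what the source reports. "The series", "measured", "known", "first", "only" and "open" are said of these compounds alone.

Measured so far:
compound 1 `Oc1ccc2nc(-c3ccccc3)cc(O)c2c1`: 0.83 ug/mL
compound 2 `CC(C)Oc1cc(-c2ccccc2)nc2ccccc12`: > 10 ug/mL

In a functional assay on L1210 (1565) cells (Mus musculus) for cytotoxicity (a lower number here means that less compound is needed, a higher number that more compound is needed for the effect), compound 1 gives 0.83 ug/mL. Compound 2 gives only a limit of this assay, > 10 ug/mL, so no number is known for it, only that it sits at the limit of > 10 ug/mL in this assay, at which 1 of the 2 values shown sits. Within the data shown here, compounds 1 and 2 differ in more than one place, so no single-point step between them can be read, and their two values stand side by side without a computed step.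

Compound 3 `CC(C)COc1cc(-c2ccccc2)nc2ccccc12` is not yet measured. It differs from compound 2 by isobutyl in place of isopropyl on an oxygen on an aromatic ring. The step that the limit leaves unreadable from compound 2 to compound 3 is expected to be none beyond the usual scatter, in either direction. Compound 3 is therefore expected to give about 15 ug/mL in this assay, within a range of 5 ug/mL to 50 ug/mL, and most probably again only as a limit rather than a number.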

Compound 3, half-maximal effective concentration: > 10 ug/mL
Compound 3 gave a limit, no number (the forecaster's own chance of this, stated with the estimate: 70%); the middle value is on the limit's open side.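

No step can be read from compound 2 to compound 3, isobutyl in place of isopropyl on an oxygen on an aromatic ring, because both compounds stand at the same limit: the limit of > 10 ug/mL in this assay, at which 2 of the 3 values shown sit.

Still open, going by these compounds, is whether these two ethers differ at all in this assay once past that limit.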